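Aminopyrimidine TLR8 agonists: side-chain terminus variation

The compounds below may be only part of what the source reports. "The series", "measured", "known", "first", "only" and "open" are said of these compounds alone.

Measured so far:
compound 1 `CCCCNc1nc(N)nc(C)c1CCCCc1ccccc1` — 857 nM
compound 2 `CCCCNc1nc(N)nc(C)c1CCCN1CCN(C)CC1` — 179 nM
compound 3 `CCCCNc1nc(N)nc(C)c1CCCN1CCCCC1` — 133 nM

All three share the same core and the butylamino substituent and differ only at the end of the chain that leaves the aromatic carbon. In an assay on HEK293 cells for agonist activity at Toll-like receptor 8 (Homo sapiens), read by spectrophotometry (a higher number here means that more compound is needed for the effect, a lower number that less compound is needed), compound 1 gives 857 nM, compound 2 gives 179 nM and compound 3 gives 133 nM. Compound 3 carries the lowest number of the three; its separation from compound 2 is a 1.3-fold lower number from compound 2 to compound 3 (0.13 log units; within the scatter), which does not allow an order between those two, whereas against compound 1 the separation is a 6.4-fold lower number from compound 1 to compound 3 (0.81 log units; beyond the scatter). Both cyclic amines moved the number in the same direction from the benzyl terminus: a 4.8-fold lower number from compound 1 to compound 2 (0.68 log units; beyond the scatter) and a 6.4-fold lower number from compound 1 to compound 3 (0.81 log units; beyond the scatter).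

Compound 4 `CCCCNc1nc(N)nc(C)c1CCC(C)(C)O` has not been measured in this assay. The change from compound 3 is 1-hydroxy-1-methylethyl in place of (piperidin-1-yl)methyl on a saturated chain carbon, two bonds along the chain from an aromatic carbon. Among the measured compounds shown here, no measured step covers a chain shortened by one atom together with loss of the ring amine in favour of a hydroxyl; the only relevant precedent is that removing a cyclic amine in favour of a non-basic terminus, as in compound 1, gave the higher number. On that basis the expected step is a 3.0-fold higher number from compound 3 to compound 4 (0.48 log units; beyond the scatter), toward a higher number, and the estimate for compound 4 in this assay is 400 nM, with a range from 120 nM to 1500 nM.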

Compound 4, half-maximal effective concentration: 3140 nM
For compound 4 the middle estimate is 7.9-fold (0.89 log units) below the measured one, and the stated range ends below it.
By their numbers in this assay, from the lowest: compounds 3 and 2 (each within the scatter of the next); then compound 1; then compound 4.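

In this assay, among the compounds shown here, the replacement of (piperidin-1-yl)methyl by 1-hydroxy-1-methylethyl gives the widest step so far, a 24-fold higher number from compound 3 to compound 4 (1.37 log units; beyond the scatter), and it carries the number past that of the benzyl terminus: compound 1 gives 857 nM and compound 4 gives 3140 nM. For the compounds shown here, the earlier compounds showed only ring-bearing termini, so this is the first sign that a terminus with no ring, and with oxygen in place of nitrogen, can sit at the high end of the range at this position; since the whole (piperidin-1-yl)methyl group leaves at once, the step cannot be divided among the ring, its nitrogen, the chain carbon and the entering hydroxyl. No supporting data are available to explain the size of this step.

The compounds shown leave open what a piperidin-1-yl group would give when attached directly at the place now held by 1-hydroxy-1-methylethyl, and what a simple hydroxyl would give at the end of the longer chain. Also open, as far as these compounds go, is how an open-chain amine such as dimethylamino, or a carboxylic acid, would compare at the same chain end.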